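Swapping the Hydroxycyclohexyl Group for an Oxanylmethyl Chain

The source may hold more compounds than are shown below. What is called first, only, known or untested is meant among the compounds shown, and "the series" means these compounds.

Of the compounds shown here, three built on one shared core have been tested in an ADME assay on S9 fraction from liver (Rattus norvegicus) for metabolic stability, with a stated time of 60 min; on this read-out higher numbers stand for a more stable compound and lower numbers for a less stable compound. Compound 2 `Cc1nc(-c2nc[nH]n2)ccc1-c1cnc2c(n1)N([C@H]1CC[C@@H](O)CC1)C(=O)CN2` gives 100%, and compound 3 `Cc1nc(-c2nc[nH]n2)ccc1-c1cnc2c(n1)N(C(C)C)C(=O)CN2` gives 100%; the two are level at the digits printed, as the step of no change at the digits printed from compound 2 to compound 3 (within the scatter) shows, and together they stand highest of the three. Compound 1 `Cc1nc(-c2nc[nH]n2)ccc1-c1cnc2c(n1)N(CCC1CCOCC1)C(=O)CN2`, which carries a 2-(oxan-4-yl)ethyl group on the ring amide nitrogen, gives 76%, the lowest number in the set. The steps of a number 24 percentage points higher from compound 1 to compound 2 (beyond the scatter) and a number 24 percentage points higher from compound 1 to compound 3 (beyond the scatter) show that trading that chain for either a 4-hydroxycyclohexyl or an isopropyl group raised the remaining fraction well beyond the scatter.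

Compound 4 `Cc1nc(-c2nc[nH]n2)ccc1-c1cnc2c(n1)N(CC1CCOCC1)C(=O)CN2` has not been measured yet. It differs from compound 2 in one place: (oxan-4-yl)methyl in place of 4-hydroxycyclohexyl on an amide-type nitrogen in a ring. The entering (oxan-4-yl)methyl group is a close relative of the 2-(oxan-4-yl)ethyl chain of compound 1, so the measured step of a number 24 percentage points higher from compound 1 to compound 2 (beyond the scatter) is the one that bears on this change, read in reverse. The estimated step of a number 18 percentage points lower from compound 2 to compound 4 (beyond the scatter) is therefore expected to give back part of that gain. Within the data shown here, only one chain-bearing compound is available for comparison, so the range is kept wide. Compound 4 is expected to give 82%, within a range from 62% to 98%.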

Compound 4, percent of the compound remaining: 100%
Beside the measured number, compound 4's estimate is 18 percentage points below it; the whole stated range lies below it.
By their numbers in this assay, from the lowest: compound 1; then compounds 2, 3 and 4 (each within the scatter of the next).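

In this assay, the steps of no change at the digits printed from compound 2 to compound 4 (within the scatter) and no change at the digits printed from compound 3 to compound 4 (within the scatter) show that the amide-type nitrogen in a ring can carry (oxan-4-yl)methyl, a group with 0 hydrogen-bond donors and an oxygen inside its ring, with no visible loss on this read-out. The oxygen-containing ring alone therefore does not go with the low number of the earlier chain-bearing compound: the step of a number 24 percentage points higher from compound 1 to compound 4 (beyond the scatter) separates two groups that share that ring and differ only in the chain joining it to the nitrogen, 2-(oxan-4-yl)ethyl and (oxan-4-yl)methyl. Nothing available explains why this difference in the chain goes with such a step.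

Compounds 2, 3 and 4 print the same number, and with a read-out of the percent remaining that number is the top of the scale, so this assay cannot tell these three apart. Going by these compounds, it remains open how a longer chain such as 3-(oxan-4-yl)propyl would read, and whether an amine such as piperidin-4-ylmethyl would read like the (oxan-4-yl)methyl group.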